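Working notes: methyl in place of chloro

The source may hold more compounds than are shown below. What is called first, only, known or untested is meant among the compounds shown, and "the series" means these compounds.

Compound 1 `Cc1cc(CNC(C)(C)C)c(O)c(Nc2nc3cc(F)c(F)cc3n2Cc2ccc(C(F)(F)F)cc2)c1`: > 99%, a limit of the assay
Compound 2 `CCNCc1cc(Cl)cc(Nc2nc3cc(F)c(F)cc3n2Cc2ccc(C(F)(F)F)cc2)c1O`: 86%

For the measured compounds named here, in an ADME assay on microsomes from liver (Mus musculus) for metabolic stability, read by LC-MS, with a stated time of 30 min, tested at 1 uM (on this read-out lower numbers stand for a less stable compound and higher numbers for a more stable compound), compound 2 gives 86%, the only actual number so far. Compound 1 reports > 99%, which is a limit and not a number.

Compound 3 `CCNCc1cc(C)cc(Nc2nc3cc(F)c(F)cc3n2Cc2ccc(C(F)(F)F)cc2)c1O` is reached from compound 2 by a single change: methyl in place of chloro on an aromatic carbon. The site of this change is para to a hydroxy group and meta to a (ethylamino)methyl group. Going by the values given here, no measured pair shows this change alone, so the expectation in this assay is no step beyond the scatter, in either direction. The estimated move is a number 3 percentage points higher from compound 2 to compound 3 (within the scatter), a small one. For compound 3 the expected value is 89%, with an estimated range of 74% to 99%.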

Compound 3, percent of the compound remaining: 93%
Estimate against measurement, compound 3: 4 percentage points below; the measured number falls inside the stated range.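

At the position para to a hydroxy group, methyl in place of chloro now forms a pair that differs in one place, and in this assay the step is a number 7 percentage points higher from compound 2 to compound 3 (within the scatter), so this swap gives no change that can be told from the scatter. On the amine nitrogen, ethyl in place of tert-butyl gives a number at least 6 percentage points lower from compound 1 to compound 3 (that floor lies within the scatter). Compound 1 stands at a limit and not at a number, so this step gives only a floor and its true size stays unknown: the limit of > 99% in this assay, at which 1 of the 3 values shown sits.

On these data alone, whether a methoxy or nitrile group at the same position, or a propyl or cyclopropyl group on the amine nitrogen, would move the number beyond the scatter stays open. Neither step yet shows which part of the structure governs this read-out.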